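Extending a Quinazoline Amine Series with an Amide Replacement

The source may hold more compounds than are shown below. What is called first, only, known or untested is meant among the compounds shown, and "the series" means these compounds.

Three compounds share a core in which an alkylamine chain hangs from one side. Compound 1 `CCNc1nc(N)nc2ccccc12` carries the shortest chain, and in an ADME assay on HEK293 cells for agonist activity at Toll-like receptor 8 (Homo sapiens), read by a luciferase reporter, with a stated time of 6 h (a higher number here means that more compound is needed for the effect, a lower number that less compound is needed), compound 1 gives 0.77 uM. Compound 2 `CCCNc1nc(N)nc2ccccc12` lengthens that chain by one carbon, and in this assay compound 2 gives 0.93 uM. The step of a 1.2-fold higher number from compound 1 to compound 2 (0.08 log units; within the scatter) shows that adding a carbon here made no difference that can be trusted. Compound 3 `CCCCNc1nc(N)nc2cccc(C)c12` lengthens the chain once more and adds a methyl to the aromatic ring; in this assay compound 3 gives 0.3 uM, the lowest of the three numbers and beyond the scatter from both compound 1 and compound 2.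

Compound 4 `CCCCNc1nc(N)nc2cccc(C(=O)NC(C)C)c12` is the next step. The change is isopropylcarbamoyl in place of methyl on an aromatic carbon; an isopropylcarbamoyl takes the place of the methyl on the aromatic carbon that sits ortho to a fused ring and meta to a fused ring. For the measured compounds named here, no measured step touches this part of the core: the only step available, the chain change from compound 1 to compound 2, lies within scatter and concerns a different position. The direction therefore cannot be read from what is known. The expectation for compound 4 is a step of a 1.2-fold higher number from compound 3 to compound 4 (0.07 log units; within the scatter), small and uncertain. Compound 4 is estimated to give 0.35 uM in this assay, within the range 0.08 uM to 1.5 uM.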

Compound 4, minimum effective concentration: 15.6 uM
Compound 4: middle estimate off by 45-fold (1.65 log units), on the low side, and the stated range ends below it.
By their numbers in this assay, from the lowest: compound 3; then compounds 1 and 2 (each within the scatter of the next); then compound 4.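

Placing isopropylcarbamoyl in place of methyl on the aromatic carbon, ortho to a fused ring and meta to a fused ring, brings a 52-fold higher number from compound 3 to compound 4 (1.72 log units; beyond the scatter) in this assay, so far more compound is needed for the effect. For the compounds shown here, the only earlier step, on the alkylamine chain, lay within the scatter and gave no information about this ring position; this new step shows that the read-out can depend strongly on which group stands there. No measurement at hand explains why this change has such a large effect.

The entering group differs from methyl in several ways at once, as it brings a carbonyl, an amide hydrogen and an isopropyl end, so the step cannot show which of these parts matters. As far as these compounds go, it also remains open whether a plain carbamoyl, a methyl ester, an amine or a carboxylic acid on this same carbon would give a number close to that of compound 3 at 0.3 uM or one closer to that of compound 4 at 15.6 uM.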